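Moving the Fluorine, Dropping the Acetyl Group

The compounds below may be only part of what the source reports. "The series", "measured", "known", "first", "only" and "open" are said of these compounds alone.

Measured so far:
compound 1, `Fc1ccc(-c2cn3ccnc3c(-c3ccc4ncn(C5CCCCC5)c4c3)n2)cc1`, 18%
compound 2, `CC(=O)c1ccc(-c2cn3ccnc3c(-c3ccc4ncn(C5CCCCC5)c4c3)n2)cc1`, 15.9%

Among the measured compounds shown here, in a functional assay on HCT-116 cells (Homo sapiens) for inhibition, read by sulforhodamine B assay, with a stated time of 48 h, tested at 10 uM (on this read-out higher numbers stand for more inhibition at the one concentration tested (going by the name of the read-out) and lower numbers for less inhibition), compound 2 gives 15.9%, one of two numbers that sit close together; its only neighbour is compound 1, and the gap a number 2.1 percentage points lower from compound 1 to compound 2 (within the scatter) lies within the scatter. Compound 3, `Fc1ccccc1-c1cn2ccnc2c(-c2ccc3ncn(C4CCCCC4)c3c2)n1`, differs from compound 2 by 2-fluorophenyl in place of 4-acetylphenyl on an aromatic carbon. For the measured compounds named here, the single measured step, a number 2.1 percentage points lower from compound 1 to compound 2 (within the scatter), also exchanged one group on an aromatic carbon and produced no change beyond the scatter, so the expected step of a number 1.1 percentage points higher from compound 2 to compound 3 (within the scatter) is likewise none beyond the scatter. Compound 3 is therefore estimated at 17%, within 4% to 34%.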

Compound 3, a percentage reported as inhibition, at one concentration (the size of the read-out at that concentration, not a potency): 25.8%
Compound 3: middle estimate off by 8.8 percentage points, on the low side; low and high end bracket the measured number.
By their numbers in this assay, from the lowest: compounds 2, 1 and 3 (each within the scatter of the next).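

In this assay, 2-fluorophenyl in place of 4-acetylphenyl (a number 9.9 percentage points higher from compound 2 to compound 3 (within the scatter)) and 2-fluorophenyl in place of 4-fluorophenyl (a number 7.8 percentage points higher from compound 1 to compound 3 (within the scatter)) both stay within the scatter. At this aromatic carbon, neither removing the acetyl group nor placing the fluorine on a different ring carbon therefore gives a change that can be told apart from the scatter. No measured evidence is available to explain these numbers. From the compounds shown here alone, it remains open whether an amine or a carboxylic acid on this phenyl ring would shift inhibition beyond the scatter. The same question holds for a longer chain at this position.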